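A few compounds are considered here, and "the series" means these few. Any claim that something is new, unique, unknown or untested is made for them only; others in the source may bear on it.

Measured in an ADME assay (liver) for metabolic stability, with Liver microsome (Homo sapiens) as the target, using microsomes; on this read-out higher numbers stand for a longer-lived compound and lower numbers for a shorter-lived compound:
- compound 1 `CCc1nc2cc(Cl)ccn2c1C(=O)NCc1ccc(-c2ccc[nH]2)cc1`: > 2 h (a limit of the assay)
- compound 2 `CCc1nc2cc(Cl)ccn2c1C(=O)NCc1ccc(N2CCCCCC2)cc1`: 0.0483 h
- compound 3 `CCc1nc2cc(Cl)ccn2c1C(=O)NCc1ccc(N2CCC(Cl)CC2)cc1`: 0.183 h

Compound 3 holds the higher of the two actual numbers, and the gap between the two is a 3.8-fold higher number from compound 2 to compound 3 (0.58 log units; beyond the scatter). The value for compound 1 is only a limit.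

The next change leads to compound 4 `CCc1nc2cc(Cl)ccn2c1C(=O)NCc1ccc(N2CCN(C(C)C)CC2)cc1`, with 4-isopropylpiperazin-1-yl in place of 4-chloropiperidin-1-yl on an aromatic carbon.

Within the data shown here, the closest precedent is the modest 3.8-fold higher number from compound 2 to compound 3 (0.58 log units; beyond the scatter), which also swaps one non-aromatic ring for another. The large steps of an at least 41-fold lower number from compound 1 to compound 2 (1.61 log units; beyond the scatter) and an at least 10-fold lower number from compound 1 to compound 3 (1.03 log units; beyond the scatter) both leave 1H-pyrrol-2-yl, a group absent from compound 3 and compound 4, so they bear less directly. With compound 3 at 0.183 h as the higher of the two numbers, a move to a lower number seems more likely than a rise. The expected change is modest: a 2.3-fold lower number from compound 3 to compound 4 (0.36 log units; beyond the scatter). In this assay compound 4 is estimated at 0.08 h, with an expected range of 0.03 h to 0.3 h.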

Compound 4, half-life: > 2 h
Compound 4: a limit, no number; the forecaster's own chance of this, stated with the estimate: 3%; middle value at least 25-fold (1.39 log units) from the limit.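

Compound 4 shows that a six-membered non-aromatic ring on this aromatic carbon need not give a short half-life in this assay: 4-isopropylpiperazin-1-yl in place of 4-chloropiperidin-1-yl gives an at least 10-fold higher number from compound 3 to compound 4 (1.03 log units; beyond the scatter), and in place of azepan-1-yl it gives an at least 41-fold higher number from compound 2 to compound 4 (1.61 log units; beyond the scatter). Among the earlier compounds, only compound 1, with its aromatic 1H-pyrrol-2-yl, reached this end of the range, so the long-lived end is not confined to an aromatic group at this place. The value of compound 4 is a limit of the assay and not a number, and the steps between compound 1 and compound 4 cannot be read: the limit of > 2 h in this assay, at which 2 of the 4 values shown sit.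

From the compounds shown here alone, whether the rise belongs to the second ring nitrogen or to the isopropyl group stays open. A morpholin-4-yl ring, or a piperazine carrying acetyl in place of isopropyl, would separate the two.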